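From a Double to a Triple Bond in the Side Chain

A few compounds are considered here, and "the series" means these few. Any claim that something is new, unique, unknown or untested is made for them only; others in the source may bear on it.

In a functional assay on L1210 cells (Mus musculus) for inhibition (a higher number here means a weaker inhibitor, a lower number a stronger inhibitor), compound 1 `Nc1ccn(C/C=C/CO)c(=O)n1` reads > 550000 nM as a limit of the assay, not as a number. Compound 2 `Cc1cn(C/C=C\CO)c(=O)[nH]c1=O` likewise reads > 1000000 nM as a limit of the assay. Compound 1 therefore offers no exact value from which to count a change. Compound 3 `Nc1ccn(CC#CCO)c(=O)n1` keeps the core of compound 1 and differs in one place 3-hydroxyprop-1-yn-1-yl in place of 3-hydroxyprop-1-en-1-yl on a saturated chain carbon bound to an aromatic nitrogen with 3-hydroxyprop-1-yn-1-yl in place of 3-hydroxyprop-1-en-1-yl on a saturated chain carbon bound to an aromatic nitrogen. Among the compounds with values here, no measured step between closely related compounds is available as a guide. With compound 1 at its limit of > 550000 nM as the only anchor, no change beyond the usual scatter is expected in this assay for this swap. The estimated step (a step that the limit leaves unreadable from compound 1 to compound 3) is expected to have no clear direction. Compound 3 is expected at 600000 nM as an estimate, with an expected range from 200000 nM to 1800000 nM in this test.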

Compound 3, half-maximal inhibitory concentration: > 550000 nM
Compound 3: no number, only a limit (the forecaster's own chance of this, stated with the estimate: 70%); the middle value does not contradict the limit.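

Compound 1 and compound 3 both stand at a limit of the assay, not at a number, so no step between them can be read: the limit of > 550000 nM in this assay, at which 2 of the 3 values shown sit.

The compounds shown leave open whether the 3-hydroxyprop-1-yn-1-yl or the 3-hydroxyprop-1-en-1-yl side chain gives the stronger inhibitor.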